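Swapping Chloro for Fluoro on the Benzylidene Ring

This account rests on a few compounds, and the source may have more. Where it says the series, first, only, none or still open, it means among the compounds named here.

Measured compounds in a functional assay on P388 cells (Mus musculus) for inhibition; on this read-out lower numbers stand for stronger inhibition and higher numbers for weaker inhibition:
- compound 1, `O=C1/C(=C/c2ccc(Cl)cc2Cl)CCCc2ccccc21`, gives 14000 nM
- compound 2, `Cc1ccccc1/C=C1\CCc2ccccc2C1=O`, gives 17700 nM
- compound 3, `O=C1/C(=C/c2ccccc2Cl)CCCc2ccccc21`, gives 12700 nM

All three share the same core, a cyclic ketone carrying an exocyclic double bond to a substituted benzene ring. Compound 3 stands within the scatter of both compound 1 and compound 2, so the three cannot be told apart on this read-out. Within the data shown here, the one single-point step measured so far, a 1.1-fold lower number from compound 1 to compound 3 (0.04 log units; within the scatter), shows that removing a chloro group from the aromatic ring left the number essentially unchanged.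

Compound 4, `O=C1/C(=C/c2ccccc2F)CCCc2ccccc21`, is the next step: fluoro in place of chloro on an aromatic carbon. Among the measured compounds shown here, no measured pair exchanges one halogen for another, so the only guide is the step from compound 1 to compound 3, which was within the scatter, together with the narrow spread across the three compounds. On that basis no step beyond the scatter is expected in this assay for compound 4, and the estimated step of a 1.0-fold higher number from compound 3 to compound 4 (0.01 log units; within the scatter) is taken as flat. Compound 4 is therefore estimated at 13000 nM, with a range from 6000 nM to 28000 nM.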

Compound 4, half-maximal inhibitory concentration: 13200 nM
Compound 4: the middle estimate sits 1.0-fold (0.01 log units) below what was measured, and the stated range covers the measured number.
By their numbers in this assay, from the lowest: compounds 3, 4, 1 and 2 (each within the scatter of the next).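

In this assay, among these compounds, the step of a 1.0-fold higher number from compound 3 to compound 4 (0.02 log units; within the scatter) is the first measured exchange of one halogen for another, and it shows that, on this aromatic carbon ortho to a large group, fluoro and chloro cannot be told apart. The earlier step of a 1.1-fold lower number from compound 1 to compound 3 (0.04 log units; within the scatter) removed a chloro group elsewhere on the ring and kept the chloro group at this place in both compounds, so it said nothing about changing the group here. No measurement at hand explains why the number stays flat for this change.

Going by these compounds, what an amine, a carboxylic acid or a longer chain at this place would do to the number remains open, since a flat result for one halogen swapped for another says little about groups of a quite different kind. The close agreement among the compounds shown also leaves open which parts of the shared core, if any, can move the number beyond the scatter.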